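Iodo to 4-methoxyphenyl: expected cytotoxicity of compound 3

The source may report more compounds than this note shows. Statements on the series, on what has been measured and on what is new or still open speak of the compounds shown alone.

Compound 1 `Cc1cc(-c2cccs2)c2ncc(CSCCc3ccccc3)n2c1`: > 50 ug/mL
Compound 2 `Cc1cc(I)c2ncc(CSCCc3ccccc3)n2c1`: > 50 ug/mL

In an ADME assay on HEL cells (Homo sapiens) for cytotoxicity, with a stated time of 3 days (on this read-out higher numbers stand for lower toxicity in this test and lower numbers for higher toxicity in this test), compound 1 gives > 50 ug/mL, a limit of the assay. Compound 2 gives > 50 ug/mL, also a limit. The step that the two limits leave unreadable from compound 1 to compound 2 cannot be read because both values sit at the limit of > 50 ug/mL in this assay, at which 2 of the 2 values shown sit. Compound 3 `COc1ccc(-c2cc(C)cn3c(CSCCc4ccccc4)cnc23)cc1` differs from compound 2 by 4-methoxyphenyl in place of iodo on an aromatic carbon. For the measured compounds named here, only the step from compound 1 to compound 2 bears on this change, and its size is not readable, so no step beyond the scatter is expected. Compound 3 is therefore expected near 60 ug/mL, between 30 ug/mL and 120 ug/mL. The step this estimate means, a step that the limit leaves unreadable from compound 2 to compound 3, is expected to stay within the scatter.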

Compound 3, half-maximal cytotoxic concentration: 19.6 ug/mL
Estimate against measurement, compound 3: 3.1-fold (0.49 log units) above; measured number outside the range, below it.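

In this assay, putting 4-methoxyphenyl in place of iodo gives an at least 2.5-fold lower number from compound 2 to compound 3 (0.40 log units; beyond the scatter), and putting it in place of thiophen-2-yl gives an at least 2.5-fold lower number from compound 1 to compound 3 (0.40 log units; beyond the scatter). This position is therefore not indifferent to what it carries: a substituent here can shift the read-out towards higher toxicity in this test, which the thiophen-2-yl and iodo compounds had not shown. The full size of both steps stays unknown because the values of compound 1 and compound 2 are limits: the limit of > 50 ug/mL in this assay, at which 2 of the 3 values shown sit.

The compounds shown do not separate the methoxy group from the aromatic ring that bears it. Going by these compounds, how a plain phenyl or an amine would read at this place stays open.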